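Replacing the phenylthiazole sulfanyl group with a benzimidazole sulfanyl group

The source may report more compounds than this note shows. Statements on the series, on what has been measured and on what is new or still open speak of the compounds shown alone.

Measured so far:
Compound 1 `CC(C)c1cc(OCC(=O)[C@H](CC(=O)O)NC(=O)[C@@H](NC(=O)COc2cccc3ccccc23)C(C)C)no1`: in a functional assay on Jurkat cells (Homo sapiens) for inhibition (a higher number here means a weaker inhibitor, a lower number a stronger inhibitor), compound 1 gives only a limit, > 200000 nM.
Compound 2 `CC(C)[C@H](NC(=O)COc1cccc2ccccc12)C(=O)N[C@@H](CC(=O)O)C(=O)CSc1nc(-c2ccccc2)cs1`: in this assay compound 2 gives only a limit, > 200000 nM.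
Compound 3 `CC(C)[C@H](NC(=O)COc1cccc2ccccc12)C(=O)N[C@@H](CC(=O)O)C(=O)CSc1nc(-c2ccccc2)c(-c2ccccc2)o1`: in this assay compound 3 gives only a limit, > 200000 nM.

Compound 2 thus stands at the limit of this assay, as do the other two measured compounds (the limit of > 200000 nM in this assay, at which 3 of the 3 values shown sit). The step that the two limits leave unreadable from compound 1 to compound 2 is therefore of unknown size. Compound 4 `CC(C)[C@H](NC(=O)COc1cccc2ccccc12)C(=O)N[C@@H](CC(=O)O)C(=O)CSc1nc2ccccc2[nH]1` differs from compound 2 by 1H-benzimidazol-2-yl in place of 4-phenyl-1,3-thiazol-2-yl on a sulfur. Within the data shown here, no measured step shows how this change acts, so no shift beyond the scatter is expected; the step that the limit leaves unreadable from compound 2 to compound 4 is the estimate. Compound 4 is expected to give about 250000 nM in this assay, between 80000 nM and 800000 nM, most likely again as a limit.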

Compound 4, half-maximal inhibitory concentration: > 200000 nM
Compound 4 was reported as a limit (the forecaster's own chance of this, stated with the estimate: 80%); the middle value does not contradict the limit.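

No step among compound 1, compound 2 and compound 4 can be read, since each result is only a limit and not a number: the limit of > 200000 nM in this assay, at which 4 of the 4 values shown sit.

On these data alone, whether any group on this shared core gives measurable inhibition in this assay, and how these groups rank, stays open.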